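A few compounds are considered here, and "the series" means these few. Any claim that something is new, unique, unknown or untested is made for them only; others in the source may bear on it.

Working notes on the series, single-concentration antiproliferative read-out.

Compound 1 `CCc1ccc2nc(C(=O)Nc3c(F)cc(-c4cccc(F)c4)cc3F)c(C)c(C(=O)O)c2c1` and compound 2 `CCOc1ccc2nc(C(=O)Nc3c(F)cc(-c4cccc(F)c4)cc3F)c(C)c(C(=O)O)c2c1` share the same core and differ only at one aromatic carbon. In a functional assay on A-375 cells (Homo sapiens) for antiproliferative activity, read by MTT assay, with a stated time of 24 h, tested at 0.01 ug/mL (a lower number here means a weaker effect, a higher number a stronger effect of the compound at the concentration tested), compound 1 gives -0.45%, and compound 2 gives 0.3%. The step of a number 0.8 percentage points higher from compound 1 to compound 2 (within the scatter) is within the scatter. Compound 2 therefore holds the higher of the two numbers recorded so far, but its gap to compound 1 is not one this assay resolves, so neither compound can be called the stronger; both numbers sit at essentially no inhibition at the concentration tested.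

Compound 3 `Cc1c(C(=O)Nc2c(F)cc(-c3cccc(F)c3)cc2F)nc2ccc(C(F)(F)F)cc2c1C(=O)O` is the next member, carrying the change (trifluoromethyl in place of ethoxy on an aromatic carbon). Going by the values given here, the only measured step bearing on this position is a number 0.8 percentage points higher from compound 1 to compound 2 (within the scatter), where a different exchange at the same carbon moved the read-out by less than the scatter. Nothing in the data points to a direction for a trifluoromethyl at this place. The expected step is a number 0.3 percentage points lower from compound 2 to compound 3 (within the scatter) in this assay, that is, none beyond the scatter. For compound 3 the estimate in this assay is 0%, with a range from -10% to 10%.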

Compound 3, a percentage reported as inhibition, at one concentration (the size of the read-out at that concentration, not a potency): 0.12%
For compound 3 the middle estimate is 0.1 percentage points below the measured one, and the stated range covers the measured number.
By their numbers in this assay, from the lowest: compounds 1, 3 and 2 (each within the scatter of the next).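

In this assay the exchange of ethoxy for trifluoromethyl gives a number 0.2 percentage points lower from compound 2 to compound 3 (within the scatter), and the exchange of ethyl for trifluoromethyl gives a number 0.6 percentage points higher from compound 1 to compound 3 (within the scatter). This aromatic carbon has now carried three different groups, one of them built from carbon and fluorine only, without any step in this read-out that can be resolved, so the earlier single exchange is no longer an isolated case. Since all three compounds remain at essentially no inhibition, the data cannot separate a position that tolerates these changes from a concentration at which none of the compounds shows an effect, and no supporting evidence bears on the result.

From the compounds shown here alone, it remains open whether an amine or a longer chain on this carbon would give a step beyond the scatter, and whether compound 1, compound 2 and compound 3 would separate at another concentration. Also open, going by these compounds, is whether a change elsewhere on the shared core, such as an amine in place of the carboxylic acid, would lift the read-out from this level.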